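Halogen swap on the arylamino group of compound 1

This account rests on a few compounds, and the source may have more. Where it says the series, first, only, none or still open, it means among the compounds named here.

Compound 1 `O=C1C(Nc2cccc(Cl)c2)=CC(=O)c2c1nc1n2[C@H]2OC[C@@H](O)[C@H]2OC1` gives 7970 nM in a functional assay on HeLa cells (Homo sapiens) for inhibition, read by sulforhodamine B assay; a higher number here means a weaker inhibitor, a lower number a stronger inhibitor. Of the two numbers shown, that of compound 1 is the higher, but the nearest neighbour, compound 3 `O=C1C=C(Nc2ccccc2)C(=O)c2c1nc1n2[C@H]2OC[C@@H](O)[C@H]2OC1` with 5620 nM, sits within the scatter of it. Compound 2 `O=C1C(NC2CC2)=CC(=O)c2c1nc1n2[C@H]2OC[C@@H](O)[C@H]2OC1` returns only a limit, > 16000 nM. Within the data shown here, the one measured step, an at least 2.0-fold higher number from compound 1 to compound 2 (0.30 log units; that floor lies within the scatter), rests on the limit of > 16000 nM in this assay, at which 1 of the 3 values shown sits, and therefore sets only a floor.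

Compound 4 `O=C1C(Nc2ccccc2F)=CC(=O)c2c1nc1n2[C@H]2OC[C@@H](O)[C@H]2OC1` differs from compound 1 by 2-fluorophenyl in place of 3-chlorophenyl on an amine nitrogen. Among the measured compounds shown here, no measured step exchanges one halogen on the phenyl ring for another; the step from compound 1 to compound 2 removes the aromatic ring altogether and so does not speak to this change, and compound 3 carries its unsubstituted phenylamino group at another position of the shared core, without a step computed against compound 1. Nothing shown points to a shift beyond the scatter in either direction, so the expected step is a 1.0-fold higher number from compound 1 to compound 4 (0.00 log units; within the scatter). Compound 4 is therefore estimated at 8000 nM, within 3000 nM to 20000 nM.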

Compound 4, half-maximal inhibitory concentration: 9820 nM
For compound 4 the middle estimate is 1.2-fold (0.09 log units) below the measured one; low and high end bracket the measured number.
By their numbers in this assay, from the lowest: compounds 3, 1 and 4 (each within the scatter of the next). At a limit, above all of these: compound 2.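

In this assay, the exchange on the amine nitrogen gives a 1.2-fold higher number from compound 1 to compound 4 (0.09 log units; within the scatter), so the numbers for these two halogenated phenyl groups cannot be told apart. The change of halogen and the change of its place on the ring come in a single step, and this pair cannot separate them. The second step, an at least 1.6-fold lower number from compound 2 to compound 4 (0.21 log units; that floor lies within the scatter), gives only a floor, and it rests on a limit: the limit of > 16000 nM in this assay, at which 1 of the 4 values shown sits.

Going by these compounds, what a methoxy group or a carboxylic acid on this phenyl ring would do to the number stays open, as does an n-butyl chain on the amine nitrogen in place of the aromatic ring. A 2-chlorophenyl or 3-fluorophenyl group would be needed to tell the halogen apart from its place on the ring.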